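A few compounds are considered here, and "the series" means these few. Any claim that something is new, unique, unknown or untested is made for them only; others in the source may bear on it.

Compound 1 `COc1cc(-c2nnc(SCc3ccccc3)n2/N=C/c2ccccc2)cc(OC)c1OC` was measured in a functional assay on HepG2 cells (Homo sapiens) for cytotoxicity, read by MTT assay, with a stated time of 48 h (a higher number here means a weaker inhibitor, a lower number a stronger inhibitor), and gives > 200000 nM, which is a limit of the assay rather than a number. Compound 2 `COc1cc(-c2nnc(SCc3ccccc3Cl)n2/N=C/c2ccccc2)cc(OC)c1OC` gives 31700 nM in this assay. Compound 3 `COc1ccc(/C=N/n2c(SCc3ccccc3Cl)nnc2-c2cc(OC)c(OC)c(OC)c2)c(OC)c1` gives > 200000 nM in this assay, again a limit and not a number.

Two of the three values sit at the same limit (the limit of > 200000 nM in this assay, at which 2 of the 3 values shown sit), so only compound 2 has a counted number. From compound 2 to compound 1 the change is hydrogen in place of chloro on an aromatic carbon, and it brings an at least 6.3-fold higher number from compound 2 to compound 1 (0.79 log units; beyond the scatter). From compound 2 to compound 3 the cores differ by 2,4-dimethoxyphenyl in place of phenyl on a carbon with a double bond to nitrogen, with an at least 6.3-fold higher number from compound 2 to compound 3 (0.79 log units; beyond the scatter). Among the measured compounds shown here, in both directions the single change away from compound 2 moves the result from a number to the limit.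

Compound 4 `COc1ccc(/C=N/n2c(SCc3ccccc3)nnc2-c2cc(OC)c(OC)c(OC)c2)c(OC)c1` has not been measured in this assay. For the measured compounds named here, it differs from compound 3 by hydrogen in place of chloro on an aromatic carbon; this is the same change as the one from compound 2 to compound 1, at the same place. Compound 3 already sits at the limit, and the earlier step of the same kind went toward weaker inhibition, so compound 4 is expected to remain at or beyond that limit, with an expected step that the limit leaves unreadable from compound 3 to compound 4. The estimate for compound 4 is 400000 nM, with a range from 150000 nM to 2000000 nM, and most likely the assay will again report only a limit.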

Compound 4, half-maximal inhibitory concentration: 60900 nM
Compound 4: middle estimate off by 6.6-fold (0.82 log units), on the high side; measured number outside the range, below it.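

Hydrogen in place of chloro gives an at least 3.2-fold lower number from compound 3 to compound 4 (0.51 log units; beyond the scatter) in this assay, and set beside the earlier step of the same change, its direction reverses between the two cores: the same change on two cores in this assay, an at least 6.3-fold higher number (0.79 log units; beyond the scatter) from compound 2 to compound 1 and an at least 3.2-fold lower number (0.51 log units; beyond the scatter) from compound 3 to compound 4, at least 20-fold (1.31 log units) apart, beyond the scatter of two such steps

The other change, 2,4-dimethoxyphenyl in place of phenyl, gives an at least 3.2-fold lower number from compound 1 to compound 4 (0.51 log units; beyond the scatter), and it too reverses when the other core is the starting point: the same change on two cores in this assay, an at least 6.3-fold higher number (0.79 log units; beyond the scatter) from compound 2 to compound 3 and an at least 3.2-fold lower number (0.51 log units; beyond the scatter) from compound 1 to compound 4, at least 20-fold (1.31 log units) apart, beyond the scatter of two such steps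

So in these four compounds, a step seen on one core cannot simply be added to another, but the sizes of these steps are only minimum values and the data do not show why the direction changes, because compound 1 and compound 3 both sit at a limit of the assay: the limit of > 200000 nM in this assay, at which 2 of the 4 values shown sit.

The compounds shown leave open whether this reversal also appears when a group such as fluoro, methyl, an amine or a carboxylic acid takes the place of the chloro on the same aromatic carbon. Also open, as far as these compounds go, are the true sizes of the steps and whether the same pattern would hold with a longer chain in place of the benzyl group on sulfur.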